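Bromo in place of benzylsulfanyl: an estimate for compound 3

The compounds below may be only part of what the source reports. "The series", "measured", "known", "first", "only" and "open" are said of these compounds alone.

Compound 1, `Nc1nc2c(Cl)c(Cl)ccc2n1COCCO`, in a functional assay on KB cells (Homo sapiens) for inhibition; a lower number here means a stronger inhibitor, a higher number a weaker inhibitor: > 100000 nM, a limit of the assay, not a number.
Compound 2, `OCCOCn1c(SCc2ccccc2)nc2c(Cl)c(Cl)ccc21`, in this assay: 35000 nM.

Among the compounds with values here, compound 2 stands on the only actual number here; compound 1 sits at a limit, (the limit of > 100000 nM in this assay, at which 1 of the 2 values shown sits). Within the data shown here, the one measured step is an at least 2.8-fold lower number from compound 1 to compound 2 (0.45 log units; beyond the scatter), benzylsulfanyl in place of amino on an aromatic carbon. Compound 3, `OCCOCn1c(Br)nc2c(Cl)c(Cl)ccc21`, differs from compound 2 in that (bromo in place of benzylsulfanyl on an aromatic carbon).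

Among the measured compounds shown here, no measured pair shows bromo on that aromatic carbon, so the step from compound 2 to compound 3 cannot be read directly. The measured step bears on it only indirectly: benzylsulfanyl entering in place of amino lowered the number, and compound 3 loses that benzylsulfanyl again, while bromo is not amino. Compound 3 is therefore expected to give a somewhat higher number than compound 2 because an at least 2.8-fold lower number from compound 1 to compound 2 (0.45 log units; beyond the scatter) runs the other way, with a real chance that only a limit is reported. The estimate for compound 3 is 70000 nM, ranging from 25000 nM to 200000 nM. This corresponds to an expected step of a 2.0-fold higher number from compound 2 to compound 3 (0.30 log units; within the scatter).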

Compound 3, half-maximal inhibitory concentration: > 100000 nM
Compound 3: no number, only a limit; the forecaster's own chance of this, stated with the estimate: 40%; at least 1.4-fold (0.15 log units) between middle value and limit.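

In this assay, replacing benzylsulfanyl with bromo on the aromatic carbon between two ring nitrogen atoms gives an at least 2.8-fold higher number from compound 2 to compound 3 (0.45 log units; beyond the scatter), so the lower number of compound 2 is now seen to be lost against a second group and not only against amino. Compound 3 gives > 100000 nM, which is a limit of the assay and not a number. Of the three groups shown on this carbon, only benzylsulfanyl, in compound 2, gives an actual number, while amino and bromo both leave the value at a limit: the limit of > 100000 nM in this assay, at which 2 of the 3 values shown sit.

Amino and bromo cannot be ranked against each other, as the step between compound 1 and compound 3 cannot be read with a limit at both ends. As far as these compounds go, it also stays open whether the lower number of compound 2 rests on the sulfur or on the six-membered aromatic ring of benzylsulfanyl, and a methylsulfanyl or a benzylamino group on the same carbon would bear on that question.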